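A few compounds are considered here, and "the series" means these few. Any claim that something is new, unique, unknown or untested is made for them only; others in the source may bear on it.

Among the compounds with values here, in a functional assay on HCT-116 cells (Homo sapiens) for inhibition, read by sulforhodamine B assay, with a stated time of 48 h (a lower number here means a stronger inhibitor, a higher number a weaker inhibitor), three compounds of the shared core have numbers so far. Compound 1 `COc1ccc(N2NC3=CC[C@@H](OC)O[C@@]3(c3ccccc3)CC2=O)cc1` gives 11300 nM, compound 2 `CO[C@@H]1CC=C2NN(c3cc4ccccc4[nH]3)C(=O)C[C@]2(C)O1` gives 18300 nM, and compound 3 `CO[C@@H]1CC=C2NN(c3ccc(Cl)cc3)C(=O)C[C@]2(C)O1` gives 35700 nM. Compound 3 shows the highest number of the three. Its nearest neighbour is compound 2, whose number is lower by a margin that stays within the usual scatter of repeated measurements, so no order between those two can be read. Compound 1 stands furthest from compound 3, with a number lower by a margin that lies beyond the scatter.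

Compound 4 `CO[C@@H]1CC=C2NN(c3cccnc3)C(=O)C[C@]2(C)O1` has not yet been measured. Relative to compound 3 it carries pyridin-3-yl in place of 4-chlorophenyl on an amide-type nitrogen in a ring. Within the data shown here, no measured pair in this set differs in one place, so there is no step of that kind to lean on. With the three measured numbers sitting close together and compound 3 at the top, the change is expected to move the number little, if at all, beyond the scatter, with no clear direction. The estimate for compound 4 in this assay is 30000 nM, with a range from 10000 nM to 90000 nM. That estimate means an expected step of a 1.2-fold lower number from compound 3 to compound 4 (0.08 log units; within the scatter).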

Compound 4, half-maximal inhibitory concentration: 17100 nM
Beside the measured number, compound 4's estimate is 1.8-fold (0.24 log units) above it; the measured number falls inside the stated range.
By their numbers in this assay, from the lowest: compounds 1, 4, 2 and 3 (each within the scatter of the next, the first and the last beyond it).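

In this assay, within the data shown here, the swap of 4-chlorophenyl for pyridin-3-yl on the amide-type nitrogen in a ring gives a 2.1-fold lower number from compound 3 to compound 4 (0.32 log units; beyond the scatter), the first step in this set that differs in one place, and it shows that this position responds to the ring it carries, if only modestly. The direction of the step also shows that, in this pair, neither the chlorine nor a ring of carbon only is needed to reach the lower number, since the entering ring carries a ring nitrogen and a hydrogen-bond acceptor in their stead. No measurement given here accounts for the step.

The single step changes the chlorine and the ring atom together, so the compounds shown do not separate the two, and a plain phenyl at this position would be needed to tell them apart. They also leave open whether the place of the ring nitrogen matters, as pyridin-2-yl or pyridin-4-yl would show, and how this position answers to a ring bearing an amine or a carboxylic acid.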